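Shortening the ring-borne chain in the sulfonate series

This account rests on a few compounds, and the source may have more. Where it says the series, first, only, none or still open, it means among the compounds named here.

Compound 1, `CCCCC1CCC(OC(=O)N[C@@H](CC(C)C)C(=O)N[C@H](C=O)C[C@@H]2CCNC2=O)CC1`, gives 63300 nM in a toxicity assay on Huh-7 cells (Homo sapiens) for cytotoxicity; a higher number here means that more compound is tolerated, a lower number that less compound is tolerated. Compound 2, `CCCC1CCC(OC(=O)N[C@@H](CC(C)C)C(=O)N[C@H](C=O)C[C@@H]2CCNC2=O)CC1`, gives > 100000 nM in this assay, which is a limit of the assay and not a number. Compound 3, `CCCCC1CCC(OC(=O)N[C@@H](CC(C)C)C(=O)N[C@@H](C[C@@H]2CCNC2=O)C(O)S(=O)(=O)O)CC1`, gives 59100 nM in this assay.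

Compound 3 and compound 1 lie within the usual scatter of one another, as a 1.1-fold lower number from compound 1 to compound 3 (0.03 log units; within the scatter) shows. Compound 4, `CCCC1CCC(OC(=O)N[C@@H](CC(C)C)C(=O)N[C@@H](C[C@@H]2CCNC2=O)C(O)S(=O)(=O)O)CC1`, differs from compound 3 by hydrogen in place of methyl on a saturated chain carbon, three bonds along the chain from a saturated ring carbon. The same change has been measured once, as an at least 1.5-fold higher number from compound 1 to compound 2 (0.19 log units; that floor lies within the scatter), where compound 2 reached the limit described by the limit of > 100000 nM in this assay, at which 1 of the 3 values shown sits. That step points, if anywhere, toward a higher number in this assay, though its floor lies within the scatter. Compound 4 is accordingly expected to give 95000 nM in this assay, between 50000 nM and 200000 nM, an expected step of a 1.6-fold higher number from compound 3 to compound 4 (0.21 log units; within the scatter).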

Compound 4, half-maximal cytotoxic concentration: > 100000 nM
Compound 4 was reported as a limit (the forecaster's own chance of this, stated with the estimate: 45%); middle value at least 1.0-fold (0.02 log units) from the limit.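

The change of butyl to propyl now has a second reading, on the core carrying hydroxy(sulfo)methyl, with an at least 1.6-fold higher number from compound 3 to compound 4 (0.22 log units; that floor lies within the scatter). Both readings point the same way, but neither floor clears the scatter: the same change on two cores in this assay, an at least 1.5-fold higher number (0.19 log units; that floor lies within the scatter) from compound 1 to compound 2 and an at least 1.6-fold higher number (0.22 log units; that floor lies within the scatter) from compound 3 to compound 4; the limit leaves it open whether they differ. The step between compound 2 and compound 4 cannot be read, since both values are limits: the limit of > 100000 nM in this assay, at which 2 of the 4 values shown sit.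

Left open is whether an ethyl chain, a longer hexyl chain or an amine on that chain would give a number that can be read against compound 3.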